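Ethynyl Gives Way to Phenyl: What Comes Next?

A few compounds are considered here, and "the series" means these few. Any claim that something is new, unique, unknown or untested is made for them only; others in the source may bear on it.

- Compound 1 `COc1ccccc1NC(=O)CCc1cccc2c1B(O)OC2`: 430 nM
- Compound 2 `C#Cc1ccccc1NC(=O)CCc1cccc2c1B(O)OC2`: 1400 nM

These values come from a functional assay on HCT-116 cells (Homo sapiens) for antiproliferative activity, read by MTT assay, with a stated time of 72 h; a higher number here means a weaker inhibitor, a lower number a stronger inhibitor. Of the two, compound 2 has the higher number, so it is the weaker inhibitor. Compound 3 `O=C(CCc1cccc2c1B(O)OC2)Nc1ccccc1-c1ccccc1` has phenyl in place of ethynyl on an aromatic carbon, ortho to a large group: phenyl in place of ethynyl on an aromatic carbon. Within the data shown here, only one measured step bears on this change, and it is modest and beyond the scatter: a 3.3-fold higher number from compound 1 to compound 2 (0.51 log units; beyond the scatter). It shows that this place responds to substitution, but it contains no phenyl, so the direction remains uncertain. A modest rise is expected, and the estimated step is a 1.4-fold higher number from compound 2 to compound 3 (0.15 log units; within the scatter). For compound 3, the estimate is 2000 nM, with an expected range of 600 nM to 7000 nM.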

Compound 3, half-maximal inhibitory concentration: 23000 nM
Estimate against measurement, compound 3: 12-fold (1.06 log units) below; measured number outside the range, above it.
By their numbers in this assay, from the lowest: compound 1; then compound 2; then compound 3.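

Phenyl in place of ethynyl brings a 16-fold higher number from compound 2 to compound 3 (1.22 log units; beyond the scatter) and phenyl in place of methoxy brings a 53-fold higher number from compound 1 to compound 3 (1.73 log units; beyond the scatter) in this assay, both large steps against the modest one seen earlier. This position therefore accepts a six-membered aromatic ring far less well than the first two compounds could reveal. No measurement at hand explains this loss. Still open, going by these compounds, is how an amine, a fluorine atom or a methyl group would compare at this place, and whether a saturated ring such as cyclohexyl would fare as poorly as phenyl.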